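The compounds below may be only part of what the source reports. "The series", "measured", "known", "first", "only" and "open" are said of these compounds alone.

Working notes on the series. In a functional assay on HepG2 cells (Homo sapiens) for inhibition, read by MTT assay, with a stated time of 48 h (on this read-out higher numbers stand for weaker inhibition and lower numbers for stronger inhibition), compound 1 `COc1cc(/C=N/Nc2nc(-c3ccc(Br)cc3)cs2)cc(Br)c1OC` gives 64600 nM and compound 2 `COc1cc(/C=N/Nc2nc(-c3cccc(Br)c3)cs2)cc(Br)c1OC` gives 66200 nM; the change a 1.0-fold higher number from compound 1 to compound 2 (0.01 log units; within the scatter) leaves the two within the scatter of each other, so neither is set apart. Compound 2 holds the higher of the two numbers in this assay, with compound 1 nearest.

Compound 3 `COc1cc(/C=N/Nc2nc(-c3ccc(F)c(F)c3)cs2)cc(Br)c1OC` is not yet measured. It differs from compound 2 by 3,4-difluorophenyl in place of 3-bromophenyl on an aromatic carbon. For the measured compounds named here, the only measured step, the move from compound 1 to compound 2, swaps one bromophenyl for another on the same carbon and registers no change in this assay beyond the scatter; no measured step addresses fluorine in place of bromine on this ring, so the expectation rests on that single step alone. A step of about the same small size in either direction is therefore expected.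

Compound 3 is estimated in this assay at 70000 nM, with a range of 30000 nM to 160000 nM, meaning a step of a 1.1-fold higher number from compound 2 to compound 3 (0.02 log units; within the scatter) that is expected to stay within the scatter.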

Compound 3, half-maximal inhibitory concentration: 22400 nM
Estimate against measurement, compound 3: 3.1-fold (0.49 log units) above, outside the stated range (below it).
By their numbers in this assay, from the lowest: compound 3; then compounds 1 and 2 (each within the scatter of the next).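

In this assay, this position on the shared core responds to the group it carries: 3,4-difluorophenyl in place of the bromophenyl groups gives a 3.0-fold lower number from compound 2 to compound 3 (0.47 log units; beyond the scatter) and a 2.9-fold lower number from compound 1 to compound 3 (0.46 log units; beyond the scatter). The earlier pair, which differ only in where the bromine sits on the phenyl, had shown no step beyond the scatter, so the position first registers a change with this exchange of group. No supporting data are available to account for this step.

Going by these compounds, it remains open whether both fluorine atoms are needed for the lower number or whether a single fluorine on the phenyl would give the same reading. Also open, on these data alone, is how a phenyl carrying an amine or a carboxylic acid would read at this position, and whether the step persists when the bromine on the shared core is exchanged.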